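Oxazole series: acetyl replacing the methylpyridyl group

This account rests on a few compounds, and the source may have more. Where it says the series, first, only, none or still open, it means among the compounds named here.

The three measured compounds share a core and differ only in the group on one aromatic carbon of the five-membered ring. In an assay (Rattus norvegicus) for inhibition of Fatty-acid amide hydrolase 1 (Homo sapiens) (a lower number here means a stronger inhibitor, a higher number a weaker inhibitor), compound 1 `O=C(CCCCCCc1ccccc1)c1ncc(-c2ccc(F)cc2)o1` gives 62 nM, compound 2 `O=C(CCCCCCc1ccccc1)c1ncc(-c2ccc(O)cc2)o1` gives 140 nM, and compound 3 `Cc1cccnc1-c1cnc(C(=O)CCCCCCc2ccccc2)o1` gives 15 nM. Compound 3 stands at the lowest number of the three: the steps of a 4.1-fold lower number from compound 1 to compound 3 (0.62 log units; beyond the scatter) and a 9.3-fold lower number from compound 2 to compound 3 (0.97 log units; beyond the scatter) both lie beyond the scatter, while a 2.3-fold higher number from compound 1 to compound 2 (0.35 log units; beyond the scatter) is the smaller move.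

Compound 4 `CC(=O)c1cnc(C(=O)CCCCCCc2ccccc2)o1` has not yet been measured. Change: acetyl in place of 3-methylpyridin-2-yl on an aromatic carbon. Among the compounds with values here, none of the measured steps exchanges a ring for a group without a ring; the two steps that bear on it, a 4.1-fold lower number from compound 1 to compound 3 (0.62 log units; beyond the scatter) and a 9.3-fold lower number from compound 2 to compound 3 (0.97 log units; beyond the scatter), show only that exchanging one aromatic ring for another on this carbon moves the number well beyond the scatter. Removing the ring altogether is a larger change than either of those, so a step back toward the numbers of compound 1 and compound 2, possibly further, is expected rather than a further gain. The expected step is a 3.3-fold higher number from compound 3 to compound 4 (0.52 log units; beyond the scatter). Compound 4 is estimated at 50 nM, with a range from 12 nM to 200 nM.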

Compound 4, inhibition constant: 2 nM
Estimate against measurement, compound 4: 25-fold (1.40 log units) above; the measured number lies below the stated range.
By their numbers in this assay, from the lowest: compound 4; then compound 3; then compound 1; then compound 2.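

Working notes: at the aromatic carbon next to the ring oxygen, an aromatic ring is not required for strong inhibition in this assay, since acetyl, which has no ring and fewer heavy atoms than 3-methylpyridin-2-yl, gives a 7.5-fold lower number from compound 3 to compound 4 (0.88 log units; beyond the scatter). Against the phenyl-bearing compounds, the exchange is larger than any step among the ring-bearing compounds, with a 31-fold lower number from compound 1 to compound 4 (1.49 log units; beyond the scatter) and a 70-fold lower number from compound 2 to compound 4 (1.85 log units; beyond the scatter), which makes compound 4 the strongest inhibitor of the four in this assay. Acetyl and 3-methylpyridin-2-yl have the same hydrogen-bond donor and acceptor counts, so these counts do not separate the two groups, and no measurement here accounts for the fall in the number.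

The compounds shown do not tell whether the gain follows the carbonyl of the acetyl group or the loss of the ring, a question that a methyl ester, a carboxylic acid, a primary amide or a simple ethyl group on the same carbon would help to settle. From the compounds shown here alone, it also stays open whether the acetyl exchange keeps its size with a shorter or longer chain between the phenyl ring and the carbonyl on the shared core.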